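The source may report more compounds than this note shows. Statements on the series, on what has been measured and on what is new or still open speak of the compounds shown alone.

Compound 1, `Cc1cccc(Cn2cc(CCCCC[C@@H]3SC[C@@H]4NC(=O)N[C@@H]43)nn2)c1`, was examined in an assay on isolated protein for inhibition of biotin--protein ligase (Homo sapiens), read by scintillation counting, with a stated time of 10 min; a lower number here means a stronger inhibitor, a higher number a weaker inhibitor. In this assay compound 1 gives > 16000 nM, which is a limit of the assay and not a number. Compound 2, `O=C1N[C@H]2[C@H](CS[C@H]2CCCCCc2cn(Cc3ccccc3Br)nn2)N1`, carries a 2-bromophenyl in place of the 3-methylphenyl on a saturated chain carbon bound to an aromatic nitrogen. In this assay compound 2 gives > 16000 nM, again a limit and not a number. The step that the two limits leave unreadable from compound 1 to compound 2 is therefore of no readable size. Compound 2 thus stands at the limit of > 16000 nM in this assay, at which 2 of the 2 values shown sit, with nothing to separate it from compound 1.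

Compound 3, `O=C1N[C@H]2[C@H](CS[C@H]2CCCCCc2cn(Cc3cccc(Cl)c3)nn2)N1`, is the next member of the set: 3-chlorophenyl in place of 2-bromophenyl on a saturated chain carbon bound to an aromatic nitrogen. Within the data shown here, the one measured step that touches the same place, a step that the two limits leave unreadable from compound 1 to compound 2, has no readable size, so neither direction nor magnitude can be taken from it. Because both measured compounds sit at the limit of > 16000 nM in this assay, at which 2 of the 2 values shown sit, the expected step that the limit leaves unreadable from compound 2 to compound 3 is one that cannot be read beyond the scatter either. Compound 3 is accordingly estimated at 20000 nM, within a range from 8000 nM to 50000 nM, and is expected most likely to be reported once more only as a limit.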

Compound 3, inhibition constant: > 16000 nM
Compound 3: only a limit was reported (the forecaster's own chance of this, stated with the estimate: 85%); the middle value is on the limit's open side.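

In this assay compound 3 gives > 16000 nM, again a limit of the assay and not a number. No step can be read among compound 1, compound 2 and compound 3: the limit of > 16000 nM in this assay, at which 3 of the 3 values shown sit. The compounds shown leave open how strongly any of the three inhibits, and whether 3-methylphenyl, 2-bromophenyl and 3-chlorophenyl differ at all.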